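From cyclohexyl to (oxan-4-yl)oxy on a carbonyl carbon

The source may report more compounds than this note shows. Statements on the series, on what has been measured and on what is new or still open speak of the compounds shown alone.

Measured in a physicochemical assay for lipophilicity, at pH 7.4; a lower number here means a more polar compound, a higher number a more lipophilic compound:
- Compound 1 `Cc1cc(C(=O)NC(C)C)nn1Cc1cc(Cl)ccc1OCc1ccccc1`: > 3.7, a limit
- Compound 2 `Cc1cc(C(=O)Nc2ccc(F)cc2)nn1Cc1cc(Cl)ccc1OCc1ccccc1`: 3
- Compound 3 `Cc1cc(NC(=O)C2CCCCC2)nn1Cc1cc(Cl)ccc1OCC(C)C`: > 3.7, a limit

Compound 3 stands only at a limit, > 3.7. Compound 4 `Cc1cc(NC(=O)OC2CCOCC2)nn1Cc1cc(Cl)ccc1OCC(C)C` carries (oxan-4-yl)oxy in place of cyclohexyl on a carbonyl carbon.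

One measured step is available, and it concerns a different change, 4-fluorophenyl in place of isopropyl on an amide-type nitrogen. It gives a number at least 0.70 log units lower from compound 1 to compound 2 (beyond the scatter). It bears only loosely, but it shows that one change in this series can move this assay beyond the scatter. On that evidence and the counted difference, a downward move is expected, with an estimated a number at least 0.30 log units lower from compound 3 to compound 4 (that floor lies within the scatter).

For compound 4 the estimate is 3.4, with an expected range from 2.9 to 3.9.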

Compound 4, distribution coefficient: 3.4
Estimate against measurement, compound 4: no gap at the digits printed; measured number inside the range.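

On this carbonyl carbon, (oxan-4-yl)oxy gives compound 4 a measured number in this assay, 3.4. Compound 3 stands at > 3.7, which is a limit. The change therefore reads only as a number at least 0.30 log units lower from compound 3 to compound 4 (that floor lies within the scatter), and its full size cannot be told: the limit of > 3.7 in this assay, at which 2 of the 4 values shown sit.

On these data alone, what a cyclohexyloxy or a plain oxan-4-yl group would give on this carbonyl carbon stays open, so any shift cannot yet be divided between the ring oxygen and the linking oxygen.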